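The source may hold more compounds than are shown below. What is called first, only, known or untested is meant among the compounds shown, and "the series" means these compounds.

The measured compounds:
compound 1, `COc1cc(OC)c(C(=O)/C=C/c2cn(-c3ccccc3)nc2-c2ccsc2)c(OC)c1`: 6100 nM
compound 2, `O=C(/C=C/c1cn(-c2ccccc2)nc1-c1cccnc1)c1ccccn1`: 6400 nM
compound 3, `COc1cc(C(=O)/C=C/c2cn(-c3ccccc3)nc2-c2cccnc2)cc(OC)c1OC`: 1900 nM

All three numbers come from a functional assay on Huh-7 cells (Homo sapiens) for inhibition, read by sulforhodamine B assay, with a stated time of 72 h; a lower number here means a stronger inhibitor, a higher number a weaker inhibitor. Compound 2 gives the highest of the three numbers shown, 6400 nM, though compound 1 lies within the scatter of it; compound 3 gives a number that lies beyond the scatter, on the lower side.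

Compound 4, `COc1ccc(C(=O)/C=C/c2cn(-c3ccccc3)nc2-c2cccnc2)c(OC)c1`, has not been measured. It differs from compound 2 in one place: 2,4-dimethoxyphenyl in place of pyridin-2-yl on a carbonyl carbon. Among the measured compounds shown here, no step between measured compounds isolates this change. What the numbers do show is that compound 3, which also carries a methoxy-bearing phenyl at that carbonyl, gives 1900 nM against compound 2 with 6400 nM. On that basis a downward step is expected, modest in size and possibly within the scatter. Compound 4 is therefore estimated at 3500 nM, in a range from 1500 nM to 8000 nM, which would mean a 1.8-fold lower number from compound 2 to compound 4 (0.26 log units; within the scatter).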

Compound 4, half-maximal inhibitory concentration: 2400 nM
Beside the measured number, compound 4's estimate is 1.5-fold (0.16 log units) above it, and the stated range covers the measured number.
By their numbers in this assay, from the lowest: compounds 3 and 4 (each within the scatter of the next); then compounds 1 and 2 (each within the scatter of the next).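

In this assay, among the compounds shown here, the change from pyridin-2-yl to 2,4-dimethoxyphenyl on a carbonyl carbon gives a 2.7-fold lower number from compound 2 to compound 4 (0.43 log units; beyond the scatter) as the first step that can be read at this position. It shows that the number responds to what sits on this carbonyl carbon, and that a carbon-only ring bearing methoxy groups can stand there with a result beyond the scatter of compound 2. Compound 4 at 2400 nM and compound 3, with its own methoxy-bearing phenyl, at 1900 nM lie within the scatter of each other, and no measurement shown gives a reason for the step.

From the compounds shown here alone, whether the step belongs to the methoxy groups or to the carbon-only ring itself stays open. A plain phenyl, or a phenyl carrying a hydroxyl or an amine in place of the methoxy groups, would be needed to separate the two.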